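Replacing the diethylamino group of compound 3

The compounds below may be only part of what the source reports. "The series", "measured", "known", "first", "only" and "open" are said of these compounds alone.

Of the compounds shown here, three have numbers so far in a functional assay on the whole organism for antagonist activity, with Mus musculus as the target; on this read-out lower numbers stand for an effect already at smaller amounts and higher numbers for an effect only at larger amounts of compound. Compound 1 `CCC(=O)N(c1ccc(C)cc1)C1CCCCC1N(C)C` reaches only a limit of this assay, > 50 mg/kg. Compound 2 `CCC(=O)N(c1ccc(C(F)(F)F)cc1)C1CCCC1N(C)C` gives 25 mg/kg. Compound 3 `CCC(=O)N(c1ccc(Cl)c(Cl)c1)C1CCCC1N(CC)CC` gives 0.03 mg/kg, the lower of the two real numbers, and its gap to compound 2 lies far beyond the usual scatter of repeated measurements.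

Compound 4 `CCC(=O)N(c1ccc(Cl)c(Cl)c1)C1CCCC1N(C)CCN(C)C` keeps the rest of compound 3 and changes one group: (2-(dimethylamino)ethyl)(methyl)amino stands in place of diethylamino on a saturated ring carbon, a swap counted as (2-(dimethylamino)ethyl)(methyl)amino in place of diethylamino on a saturated ring carbon. Going by the values given here, no measured pair of compounds shows this change on its own, so any forecast is rough. Compound 3 starts very low at 0.03 mg/kg, which leaves much more room for the number to rise than to fall. The expected move is a 100-fold higher number from compound 3 to compound 4 (2.00 log units; beyond the scatter), a large step beyond the scatter towards a higher number, meaning that more compound would be needed for the same effect. Compound 4 is estimated at 3 mg/kg, with an expected range from 0.3 mg/kg to 30 mg/kg.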

Compound 4, dose for half-maximal effect: 5 mg/kg
Beside the measured number, compound 4's estimate is 1.7-fold (0.22 log units) below it; the measured number falls inside the stated range.
By their numbers in this assay, from the lowest: compound 3; then compound 4; then compound 2. At a limit, above all of these: compound 1.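

In this assay, going by these compounds alone, this saturated ring carbon proves sensitive to which amino group it carries: changing only this group, with (2-(dimethylamino)ethyl)(methyl)amino in place of diethylamino, gives a large step beyond the scatter (a 170-fold higher number from compound 3 to compound 4 (2.22 log units; beyond the scatter)). The very low number of compound 3 therefore depends on the group at this position, and the rest of the molecule does not preserve it. Compound 4 still gives a real number rather than a limit, but nothing shown gives a measured reason for this step.

From the compounds shown here alone, the new group differs from diethylamino in both its larger size and its added nitrogen, so it remains open which of these matters more. A dipropylamino group, whose chains hold only carbon, at the same position would help to separate the two.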